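The compounds below may be only part of what the source reports. "The series", "measured", "known", "first", "only" and "open" are said of these compounds alone.

Of the compounds shown here, three built on one shared core have been tested in an assay on isolated protein for inhibition of acyl-CoA desaturase 1 (Mus musculus); on this read-out lower numbers stand for stronger inhibition and higher numbers for weaker inhibition. Compound 1 `CNC(=O)c1cccc(NC(=O)N2CCC(Oc3ccccc3Cl)CC2)c1` carries a methylcarbamoyl group on the aromatic ring. In this assay compound 1 gives < 4 nM, which is a limit of the assay rather than a number, (the limit of < 4 nM in this assay, at which 1 of the 3 values shown sits). Compound 2 `Cc1noc(-c2cccc(NC(=O)N3CCC(Oc4ccccc4Cl)CC3)c2)n1` carries a 3-methyl-1,2,4-oxadiazol-5-yl group in that place and gives 8 nM. Compound 3 `NC(=O)c1cccc(NC(=O)N2CCC(Oc3ccccc3Cl)CC2)c1` carries a plain carbamoyl group and gives 10 nM. Among the two plain numbers compound 3 has the larger one, but the step of a 1.3-fold higher number from compound 2 to compound 3 (0.10 log units; within the scatter) is within the scatter, so the two cannot be told apart. The step of an at least 2.5-fold higher number from compound 1 to compound 3 (0.39 log units; beyond the scatter), removing the methyl from the amide nitrogen, weakens inhibition at least modestly.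

Compound 4 `CC(C)NC(=O)c1cccc(NC(=O)N2CCC(Oc3ccccc3Cl)CC2)c1` has not yet been measured. It differs from compound 3 in one place: isopropyl in place of hydrogen on an amide-type nitrogen. For the measured compounds named here, only the step from compound 1 to compound 3 touches this position, and it runs in the opposite direction, so putting a carbon group back onto the amide nitrogen is expected to lower the number again. Compound 4 is therefore expected to show a step of a 2.0-fold lower number from compound 3 to compound 4 (0.30 log units; within the scatter), giving an estimated 5 nM in this assay, with a range from 2 nM to 15 nM.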

Compound 4, half-maximal inhibitory concentration: 810 nM
Compound 4: middle estimate off by 160-fold (2.21 log units), on the low side; measured number outside the range, above it.
By their numbers in this assay, from the lowest: compounds 2 and 3 (each within the scatter of the next); then compound 4. At a limit, below all of these: compound 1.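

In this assay, putting isopropyl on the amide nitrogen gives an 81-fold higher number from compound 3 to compound 4 (1.91 log units; beyond the scatter), so a carbon group at this position does not by itself strengthen inhibition; which group it is matters greatly. Methyl and isopropyl on this same nitrogen lead to very different results, with an at least 200-fold higher number from compound 1 to compound 4 (2.30 log units; beyond the scatter), and compound 4 also falls well short of the oxadiazole compound, with a 100-fold higher number from compound 2 to compound 4 (2.01 log units; beyond the scatter). The size of the methyl-to-isopropyl step is only a floor, as compound 1 is recorded at a limit of the assay rather than as a number: the limit of < 4 nM in this assay, at which 1 of the 4 values shown sits.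

The compounds shown leave open where between methyl and isopropyl inhibition is lost, which an ethyl group or a cyclopropyl group on the amide nitrogen could help to locate, and whether a longer chain behaves like isopropyl. They also cannot explain the loss seen with isopropyl, and they do not tell whether a second methyl on the same nitrogen, which would replace the amide hydrogen, would be accepted.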